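A few compounds are considered here, and "the series" means these few. Any claim that something is new, unique, unknown or untested is made for them only; others in the source may bear on it.

Of the compounds shown here, three have been measured in a functional assay on T47D cells (Homo sapiens) for antiproliferative activity, read by MTT assay, with a stated time of 48 h; on this read-out lower numbers stand for stronger inhibition and higher numbers for weaker inhibition. Compound 1 `COc1cc(/C=N/c2c(C#N)ncn2Cc2ccc(F)cc2)cc(OC)c1OC` and compound 2 `COc1ccc(/C=N/c2c(C#N)ncn2Cc2ccc(F)cc2)cc1OC` share one core and differ in a single place: methoxy in place of hydrogen on an aromatic carbon. In this assay compound 2 gives 8200 nM, while compound 1 gives 17500 nM; the step is a 2.1-fold higher number from compound 2 to compound 1 (0.33 log units; beyond the scatter).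

Compound 3 `COc1ccc(C2N=C(C(N)=O)c3ncn(-c4ccc(F)cc4)c3N2)cc1` is built on a different core; the difference between the two cores is not broken down here. In this assay compound 3 gives 5870 nM, which sits within the scatter of compound 2 and beyond it from compound 1.

Among the measured compounds shown here, compound 4 `COc1ccc(C2N=C(C(N)=O)c3ncn(-c4ccc(F)cc4)c3N2)cc1OC` is the only compound not yet measured. It differs from compound 3 in one place: methoxy in place of hydrogen on an aromatic carbon. For the measured compounds named here, this is the same kind of change as the one from compound 2 to compound 1, though not the same: in compound 1 the entering methoxy is also meta to a methoxy group, a feature absent in compound 4.

Going by the values given here, for compound 4 the expected step is a 1.6-fold higher number from compound 3 to compound 4 (0.21 log units; within the scatter), resting on the one measured example, a 2.1-fold higher number from compound 2 to compound 1 (0.33 log units; beyond the scatter), carried over to a core where this change has not been tested, so the direction is taken from that example but with wider uncertainty. Compound 4 is therefore expected to give 9500 nM in this assay, within a range from 3500 nM to 26000 nM.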

Compound 4, half-maximal inhibitory concentration: 9960 nM
The estimate for compound 4 lay 1.0-fold (0.02 log units) below the measured number, and the stated range covers the measured number.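

In this assay, the added methoxy gives a 1.7-fold higher number from compound 3 to compound 4 (0.23 log units; within the scatter), so on its own this step cannot be told apart from the ordinary differences between repeated measurements. Set beside the same change on the other core, the two steps agree in direction, and the gap between them is no larger than such measurements would produce: the same change on two cores in this assay, a 2.1-fold higher number (0.33 log units; beyond the scatter) from compound 2 to compound 1 and a 1.7-fold higher number (0.23 log units; within the scatter) from compound 3 to compound 4, 1.3-fold (0.10 log units) apart, within the scatter of two such steps. This shows that, across these two pairs, what was seen on the core of compound 2 carried over to the core of compound 3 without any detectable difference, but two pairs make a small sample and do not establish a rule for the series, nor do they explain why the numbers move as they do.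

The compounds shown have only hydrogen or methoxy at this place, which leaves open how a hydroxyl group, an amine, a chlorine atom or a longer chain such as ethoxy would read there in this assay. They also leave open whether the methoxy step would look the same on a third core, or in a cell line other than the one used here.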